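Nitrofuran amides: trifluoromethoxy in place of methoxy

The source may report more compounds than this note shows. Statements on the series, on what has been measured and on what is new or still open speak of the compounds shown alone.

Measured so far:
compound 1 `O=C(NCCCc1ccccc1)c1ccc([N+](=O)[O-])o1`, an ADME assay on Vero cells (Chlorocebus sabaeus) for cytotoxicity, read by MTT assay, with a stated time of 48 h; a lower number here means that less compound is tolerated, a higher number that more compound is tolerated: 11000 nM
compound 2 `COc1ccc(C(C)(C)NC(=O)c2ccc([N+](=O)[O-])o2)cc1`, this assay: 82000 nM

In this assay compound 2 gives the higher of the two numbers, with compound 1 giving a value that is beyond the scatter below it. Compound 3 `CC(C)(NC(=O)c1ccc([N+](=O)[O-])o1)c1ccc(OC(F)(F)F)cc1` differs from compound 2 by trifluoromethyl in place of methyl on an oxygen on an aromatic ring. Going by the values given here, no step between measured compounds covers this change, so the direction rests on the change alone. A step of this kind is expected to stay near the scatter, with a lower number somewhat more likely than a higher one, so compound 3 is expected at 50000 nM, between 15000 nM and 150000 nM, which means a step of a 1.6-fold lower number from compound 2 to compound 3 (0.21 log units; within the scatter).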

Compound 3, half-maximal cytotoxic concentration: 70000 nM
Compound 3: the middle estimate sits 1.4-fold (0.15 log units) below what was measured, within the range that was stated.
By their numbers in this assay, from the lowest: compound 1; then compounds 3 and 2 (each within the scatter of the next).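

Trifluoromethyl in place of methyl on an oxygen on an aromatic ring gives a 1.2-fold lower number from compound 2 to compound 3 (0.07 log units; within the scatter) in this assay. Going by these compounds alone, this is the first comparison here in which only one place differs, and at this place the two groups cannot be told apart in this read-out. No other measurement bears on why the two compounds stand so close.

As far as these compounds go, it remains open whether an amine, a carboxylic acid or a longer chain at this place would stay as close to methoxy. One pair also cannot show whether the same exchange would read alike on another core.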